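A few compounds are considered here, and "the series" means these few. Any claim that something is new, unique, unknown or untested is made for them only; others in the source may bear on it.

Compound 1 `O=C(Nc1ccc(F)cc1)C(Cl)Cl` has no result in a functional assay on Bel-7402 cells (Homo sapiens) for antiproliferative activity, read by MTT assay, with a stated time of 72 h (a lower number here means a stronger inhibitor, a higher number a weaker inhibitor), to show: the entry for compound 1 reads "not determined" (no result reported), so it offers no number to build on. Compound 2 `O=C(Nc1ccc(Br)cc1)C(Cl)Cl` is the one compound with a measured value: in this assay compound 2 gives 9770 nM, which makes it the only number shown, with compound 1 standing beside it as an entry without a single number. Within the data shown here, there is no pair of measured compounds that differ in one place, so no measured step sets a scale for what a single change at the ring does here.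

Compound 3 `COc1ccc(NC(=O)C(Cl)Cl)cc1` differs from compound 2 in one way: methoxy in place of bromo on an aromatic carbon, on an aromatic carbon of a six-membered aromatic ring of carbon only. Since no step is shown, the expected size of this change is open; the working expectation is a step no larger than the usual scatter, with a slight lean toward a weaker inhibitor. On that basis, compound 3 is estimated to give 12000 nM in this assay, within a range from 4000 nM to 40000 nM, which corresponds to an expected step of a 1.2-fold higher number from compound 2 to compound 3 (0.09 log units; within the scatter).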

Compound 3, half-maximal inhibitory concentration: 192000 nM
Compound 3: middle estimate off by 16-fold (1.20 log units), on the low side; measured number outside the range, above it.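

In this assay, putting methoxy in place of bromo gives a 20-fold higher number from compound 2 to compound 3 (1.29 log units; beyond the scatter), and this first measured step shows that the position, on an aromatic carbon of a six-membered aromatic ring of carbon only, is not indifferent to the group it carries. Here, one heavy atom leaves and two enter, with one hydrogen-bond acceptor gained and no net charge on either side, and that single change moves the number well beyond the scatter towards a weaker inhibitor, giving this series its first scale for a change at this place. Nothing measured among the compounds shown accounts for the size of this step, and its cause stays unknown.

Since this is a single step, it cannot separate the loss of bromo from the arrival of methoxy, and compound 1, with its fluoro group, adds no number to help decide between them. The compounds shown also leave open how this position would respond to an amine, a carboxylic acid or a longer chain such as butoxy, and whether any group there would give a stronger inhibitor than compound 2.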